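The compounds below may be only part of what the source reports. "The series", "measured", "known", "first", "only" and "open" are said of these compounds alone.

Measured in an ADME assay on MT2 cells (Homo sapiens) for cytotoxicity, read by XTT assay, with a stated time of 4 days; on this read-out higher numbers stand for lower toxicity in this test and lower numbers for higher toxicity in this test:
- Compound 1 `Cc1ccc(NC(=O)C(=O)NC(c2nc(C)c(CCO)s2)C2CCCCN2)cc1F`: 85000 nM.
- Compound 2 `Cc1nc(C(NC(=O)C(=O)Nc2ccc(Cl)cc2)C2CCNCC2)sc1CCO`: > 78500 nM, which is a limit of the assay and not a number.
- Compound 3 `CCn1cc(NC(=O)C(=O)Nc2ccc(Cl)cc2)cn1`: 10700 nM.

Of the two exact numbers, compound 1 holds the higher, and the gap down to compound 3 lies beyond the scatter. Compound 4 `Cc1ccc(NC(=O)C(=O)NC(c2nc(C)c(CCO)s2)C2CCCCN2)c(F)c1` keeps the same atoms but joins them differently: 2-fluoro-4-methylphenyl in place of 3-fluoro-4-methylphenyl on an amide-type nitrogen. In words, 2-fluoro-4-methylphenyl stands in place of 3-fluoro-4-methylphenyl on an amide-type nitrogen. Among the measured compounds shown here, no measured pair shows what such a change does, so no step beyond the scatter is expected in this assay, and no direction is favoured. The estimated step is a 1.2-fold lower number from compound 1 to compound 4 (0.08 log units; within the scatter). The expected value for compound 4 is 70000 nM, within an estimated range of 30000 nM to 130000 nM.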

Compound 4, half-maximal cytotoxic concentration: > 78800 nM
Compound 4: only a limit was reported; the forecaster's own chance of this, stated with the estimate: 35%; at least 1.1-fold (0.05 log units) between middle value and limit.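

Compound 4 gives > 78800 nM, a limit of the assay and not a number, so its step from compound 1 cannot be read. The compounds shown leave open whether 2-fluoro-4-methylphenyl in place of 3-fluoro-4-methylphenyl changes the number at all.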